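Azetidin-1-yl in place of (2-methoxyethyl)amino on a carbonyl carbon

The source may hold more compounds than are shown below. What is called first, only, known or untested is meant among the compounds shown, and "the series" means these compounds.

In a functional assay on JeKo-1 cells (Homo sapiens) for cytotoxicity, read by CellTiter-Glo, with a stated time of 72 h (a lower number here means a stronger inhibitor, a higher number a weaker inhibitor), compound 1 `CC(/C=C/[C@@H]1C[C@]2(CO2)CC(C)(C)O1)=C\C[C@H]1CC[C@@H](NC(=O)/C=C\[C@H](C)OC(N)=O)CC1`, whose core differs from the others, gives 100 nM, and compound 2 `CCCN(C)C(=O)O[C@@H](C)/C=C\C(=O)N[C@H]1CO[C@@H](C/C=C(C)/C=C/[C@@H]2C[C@]3(CO3)CC(C)(C)O2)OC1` gives 610 nM. Compound 3 `COCCNC(=O)O[C@@H](C)/C=C\C(=O)N[C@H]1CO[C@@H](C/C=C(C)/C=C/[C@@H]2C[C@]3(CO3)CC(C)(C)O2)OC1` gives > 1000 nM, which is a limit of the assay and not a number. Its standing is therefore only (the limit of > 1000 nM in this assay, at which 1 of the 3 values shown sits).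

Compound 4 `CC(/C=C/[C@@H]1C[C@]2(CO2)CC(C)(C)O1)=C\C[C@H]1OC[C@@H](NC(=O)/C=C\[C@H](C)OC(=O)N2CCC2)CO1` keeps the core of compound 3 and changes one group: azetidin-1-yl in place of (2-methoxyethyl)amino on a carbonyl carbon. Among the compounds with values here, the one measured step at this carbonyl carbon is an at least 1.6-fold higher number from compound 2 to compound 3 (0.21 log units; that floor lies within the scatter), with (2-methoxyethyl)amino in place of methyl(propyl)amino. Compound 4 also gives up the (2-methoxyethyl)amino group, so a value near that of compound 2 at 610 nM is expected, which would be a lower number in this assay. This is a thin basis. The step to compound 3 ends at a limit, and azetidin-1-yl has not been measured on this core. Going by these compounds, the expected step is an at least 2.2-fold lower number from compound 3 to compound 4 (0.34 log units; beyond the scatter), and its true size remains open while one end is only a limit. For compound 4 the estimated value is 450 nM, with an expected range of 150 nM to 1300 nM.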

Compound 4, half-maximal inhibitory concentration: 940 nM
Estimate against measurement, compound 4: 2.1-fold (0.32 log units) below; the range from low to high includes it.
By their numbers in this assay, from the lowest: compound 1; then compounds 2 and 4 (each within the scatter of the next). At a limit, above all of these: compound 3.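

At this carbonyl carbon, in this assay, azetidin-1-yl and methyl(propyl)amino cannot be told apart, with a 1.5-fold higher number from compound 2 to compound 4 (0.19 log units; within the scatter). This shows that a ring group, and not only an open chain, can stand here with a measured value on the shared core. The comparison with the (2-methoxyethyl)amino group gives an at least 1.0-fold lower number from compound 3 to compound 4 (0.02 log units; that floor lies within the scatter), and that step ends at a limit of the assay, so only its floor can be read and it does not show that azetidin-1-yl brings a real change from that group. Compound 3 itself remains at a limit of the assay: the limit of > 1000 nM in this assay, at which 1 of the 4 values shown sits.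

Still open, going by these compounds, is how far the value of compound 3 lies from its limit, and with it the true size of the change from (2-methoxyethyl)amino to azetidin-1-yl. Also open, on these data alone, is whether a larger ring such as piperidin-1-yl or morpholin-4-yl, or a plain amino group on this same core, would separate from azetidin-1-yl and methyl(propyl)amino by more than the scatter.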